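From Isobutyl to Sec-Butyl on a Shared Core

This account rests on a few compounds, and the source may have more. Where it says the series, first, only, none or still open, it means among the compounds named here.

Three compounds share one core and differ only in the group on a nitrogen on an aromatic ring: compound 1 `CSc1nc(NC2CC2)c2cccnc2n1`, compound 2 `CSc1nc(NC2CCCCC2)c2cccnc2n1` and compound 3 `CSc1nc(NCC(C)C)c2cccnc2n1`. In a functional assay (Nicotiana tabacum) (on this read-out higher numbers stand for weaker inhibition and lower numbers for stronger inhibition), compound 1 gives 4900 nM, compound 2 gives 5650 nM and compound 3 gives 540 nM. Compound 3 therefore has the lowest number of the three and is the strongest inhibitor so far.

Compound 4 `CCC(C)Nc1nc(SC)nc2ncccc12` has sec-butyl in place of isobutyl at that nitrogen: sec-butyl in place of isobutyl on a nitrogen on an aromatic ring. The two compounds contain the same atoms, joined differently.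

Among the measured compounds shown here, no measured step makes this exact swap, so the evidence is indirect. Two steps show how much this group can matter: a 9.1-fold lower number from compound 1 to compound 3 (0.96 log units; beyond the scatter) and a 10-fold lower number from compound 2 to compound 3 (1.02 log units; beyond the scatter). By contrast, a 1.2-fold higher number from compound 1 to compound 2 (0.06 log units; within the scatter) shows that two quite different rings can give matching results. Isobutyl is the only open chain measured so far, and sec-butyl is also an open chain, but nothing yet shows whether it performs as well. Part of the advantage of compound 3 is expected to be lost.

The expected change is a 2.6-fold higher number from compound 3 to compound 4 (0.41 log units; beyond the scatter), which is smaller than the two large steps. For compound 4 the estimated value in this assay is 1400 nM, with an expected range from 450 nM to 4500 nM.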

Compound 4, half-maximal inhibitory concentration: 860 nM
Compound 4: middle estimate off by 1.6-fold (0.21 log units), on the high side, and the stated range covers the measured number.
By their numbers in this assay, from the lowest: compounds 3 and 4 (each within the scatter of the next); then compounds 1 and 2 (each within the scatter of the next).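

In this assay, sec-butyl in place of isobutyl on a nitrogen on an aromatic ring gives a 1.6-fold higher number from compound 3 to compound 4 (0.20 log units; within the scatter) and so leaves the two open chains, built from the same atoms but joined differently, indistinguishable on this read-out. The clear gain over the rings is therefore not unique to isobutyl: replacing cyclohexyl with sec-butyl gives a 6.6-fold lower number from compound 2 to compound 4 (0.82 log units; beyond the scatter) and replacing cyclopropyl with sec-butyl gives a 5.7-fold lower number from compound 1 to compound 4 (0.76 log units; beyond the scatter) in the same place, beyond the scatter in both cases. Among these four compounds, then, both open chains give lower numbers than both rings, with no compound going against that split, yet nothing available here explains why the groups divide in this way.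

The compounds shown leave open whether the result holds beyond these two chains of matching atoms, for example with a longer chain such as n-hexyl or with a chain carrying an amine or a hydroxyl group. They also leave open whether a ring as such goes with the higher numbers, since a group such as cyclopropylmethyl, which joins a ring to the nitrogen through a carbon chain, is not among them.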